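A few compounds are considered here, and "the series" means these few. Any claim that something is new, unique, unknown or untested is made for them only; others in the source may bear on it.

In a functional assay (QGY7701 cells, Homo sapiens) for inhibition, read by MTT assay, with a stated time of 48 h (on this read-out lower numbers stand for stronger inhibition and higher numbers for weaker inhibition), compound 1 `COc1ccc2c(=O)c(/C=C/C(=O)Nc3ccccc3)coc2c1` gives 14000 nM, compound 2 `COc1ccc2c(=O)c(/C=C/C(=O)Nc3ccccc3Cl)coc2c1` gives 23000 nM and compound 3 `COc1cccc(NC(=O)/C=C/c2coc3cc(OC)ccc3c2=O)c1` gives 39100 nM. Two steps place compound 3: a 2.8-fold higher number from compound 1 to compound 3 (0.45 log units; beyond the scatter) and a 1.7-fold higher number from compound 2 to compound 3 (0.23 log units; within the scatter). Compound 4 `COc1ccc(NC(=O)/C=C/c2coc3cc(OC)ccc3c2=O)cc1` has the same atoms as compound 3, joined differently, with 4-methoxyphenyl in place of 3-methoxyphenyl on an amide-type nitrogen. For the measured compounds named here, no measured pair tests this swap directly. The closest guides are the methoxy step already given and the chloro step, a 1.6-fold higher number from compound 1 to compound 2 (0.22 log units; within the scatter), and neither is large. The expected change is therefore small, with no shift beyond the scatter, and the estimated step is a 1.3-fold lower number from compound 3 to compound 4 (0.12 log units; within the scatter). The estimate for compound 4 is 30000 nM, with an expected range of 14000 nM to 62000 nM.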

Compound 4, half-maximal inhibitory concentration: > 100000 nM
Compound 4 gave a limit, no number; the forecaster's own chance of this, stated with the estimate: 5%; middle value at least 3.3-fold (0.52 log units) from the limit.
By their numbers in this assay, from the lowest: compounds 1, 2 and 3 (each within the scatter of the next, the first and the last beyond it). At a limit, above all of these: compound 4.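

In this assay compound 4 gives only a limit, not a number: the limit of > 100000 nM in this assay, at which 1 of the 4 values shown sits. Moving the methoxy to give 4-methoxyphenyl in place of 3-methoxyphenyl on the amide-type nitrogen, with no atom gained or lost, gives an at least 2.5-fold higher number from compound 3 to compound 4 (0.40 log units; beyond the scatter), so where the methoxy sits matters here, not only that it is present. The other two steps read the same way: an at least 4.3-fold higher number from compound 2 to compound 4 (0.63 log units; beyond the scatter) and an at least 7.1-fold higher number from compound 1 to compound 4 (0.85 log units; beyond the scatter). On these data alone, how far compound 4 lies past its limit stays open. So does whether an amine or a carboxylic acid in place of the methoxy of 4-methoxyphenyl would also reach this limit.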